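A few compounds are considered here, and "the series" means these few. Any claim that something is new, unique, unknown or untested is made for them only; others in the source may bear on it.

In a functional assay on AGS cells (Homo sapiens) for cytotoxicity, read by sulforhodamine B assay, with a stated time of 48 h (a higher number here means a weaker inhibitor of growth, a lower number a stronger inhibitor of growth), compound 1, `CCn1cc(-c2nc3ccccc3[nH]2)c(=O)c2cc(F)c(N3CCNCC3)cc21`, gives 9500 nM, the higher of the two numbers recorded. Compound 2, `CCn1cc(-c2nc3ccc([N+](=O)[O-])cc3o2)c(=O)c2cc(F)c(N3CCNC(C)C3)c(F)c21`, gives 700 nM in this assay, a lower number that lies beyond the scatter; the two structures differ in several places, so the gap tells nothing about any single change. Compound 3, `CCn1cc(-c2nc3ccc(N)cc3[nH]2)c(=O)c2cc(F)c(N3CCNCC3)cc21`, follows from compound 1 by one change: amino in place of hydrogen on an aromatic carbon. For the measured compounds named here, no measured pair shows this change, so the step of a 1.4-fold lower number from compound 1 to compound 3 (0.13 log units; within the scatter) is expected to stay within the scatter. Compound 3 is therefore estimated at 7000 nM in this assay, with a range from 2000 nM to 25000 nM.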

Compound 3, concentration for 50% growth inhibition: 7800 nM
For compound 3 the middle estimate is 1.1-fold (0.05 log units) below the measured one; the range from low to high includes it.
By their numbers in this assay, from the lowest: compound 2; then compounds 3 and 1 (each within the scatter of the next).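

In this assay, amino in place of hydrogen on an aromatic carbon gives a 1.2-fold lower number from compound 1 to compound 3 (0.09 log units; within the scatter), the first single-change step read at this position. On this pair, the amino group leaves the number indistinguishable from that of the unsubstituted core of compound 1. No available evidence bears on this result. From the compounds shown here alone, it remains open whether a carboxylic acid, a methoxy group or a longer amine chain at this position would move the number beyond the scatter. Whether the same change behaves alike on another core is also unresolved.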